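The compounds below may be only part of what the source reports. "The series", "measured", "known", "first", "only" and "open" are said of these compounds alone.

Measured in a functional assay on HeLa cells (Homo sapiens) for antiproliferative activity, read by CCK-8 assay, with a stated time of 72 h; a lower number here means a stronger inhibitor of growth, a higher number a weaker inhibitor of growth:
- compound 1 `CCC1C(=O)N(C)c2cnc(-n3ccc4cc(C(=O)NC(C)C)ccc43)nc2N1c1ccn(C)n1`: 4350 nM
- compound 2 `CC[C@@H]1C(=O)N(C)c2cnc(Nc3ccc(S(N)(=O)=O)cc3)nc2N1C1CCCC1`: 317 nM
- compound 3 `CC[C@@H]1C(=O)N(C)c2cnc(-n3ccc4cc(C(=O)NC)ccc43)nc2N1C1CCCC1`: 768 nM

Compound 1 has the highest number of the three and is the weakest inhibitor of growth, with compound 3 and compound 2 both lower by more than the scatter. The unmeasured compound 4 `CCC1C(=O)N(C)c2cnc(-n3ccc4cc(C(=O)NC5CCCC5)ccc43)nc2N1c1ccn(C)n1` keeps the core of compound 1 and carries cyclopentyl in place of isopropyl on an amide-type nitrogen. Among the measured compounds shown here, no two measured compounds differ in one place, so the data give no direct guide to this change. Starting from compound 1 at 4350 nM, a small step towards a lower number, within the scatter, is expected in this assay. The estimated step is a 1.5-fold lower number from compound 1 to compound 4 (0.16 log units; within the scatter). The expected value for compound 4 is 3000 nM, with an estimated range of 1200 nM to 7500 nM.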

Compound 4, concentration for 50% growth inhibition: 27400 nM
Compound 4: middle estimate off by 9.1-fold (0.96 log units), on the low side; the measured number lies above the stated range.
By their numbers in this assay, from the lowest: compound 2; then compound 3; then compound 1; then compound 4.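

In this assay, cyclopentyl in place of isopropyl on the amide-type nitrogen gives a 6.3-fold higher number from compound 1 to compound 4 (0.80 log units; beyond the scatter) and the step lies beyond the scatter. Among the compounds shown here, this is the first sign that this position responds to the group it carries, and here the change to a five-membered ring of carbon goes with weaker growth inhibition. Nothing available accounts for this step. Still open, on these data alone, is whether cyclopropyl or a chain ending in an amine on this nitrogen would follow isopropyl or cyclopentyl. As far as these compounds go, whether the step holds on the core of compound 3 also remains open.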